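The source may report more compounds than this note shows. Statements on the series, on what has been measured and on what is new or still open speak of the compounds shown alone.

Compound 1, with the structure `COc1nc(-c2ccccc2F)ccc1[C@@H](c1ccccc1)[C@@](O)(CCN(C)C)c1cccc2ccccc12`, is the starting point here. In a toxicity assay on HeLa cells (Homo sapiens) for cytotoxicity (a lower number here means that less compound is tolerated, a higher number that more compound is tolerated), compound 1 has the entry "nd" (no result reported), meaning that no result was reported for it. Compound 2, with the structure `COc1ncc(-c2ccccc2)cc1[C@@H](c1ccccc1)[C@@](O)(CCN(C)C)c1cc(F)ccc1F`, stands in the same position: in this assay compound 2 has the entry "nd" (no result reported), again with no number behind it. Within the data shown here, the only number in the set belongs to compound 3, with the structure `COc1ncc(-c2ccccc2)cc1[C@@H](c1ccccc1)[C@@](O)(CCN(C)C)c1cc(F)cc(F)c1`: in this assay compound 3 gives 28.8 ug/mL. Among the measured compounds shown here, no step between measured compounds can be drawn from these three entries, so compound 1 cannot be placed on a scale; only compound 3 offers a measured point of reference.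

The change under consideration leads from compound 1 to compound 4, with the structure `COc1nc(-c2ccncc2)ccc1[C@@H](c1ccccc1)[C@@](O)(CCN(C)C)c1cccc2ccccc12`. It consists of pyridin-4-yl in place of 2-fluorophenyl on an aromatic carbon. For the measured compounds named here, with no measured pair to lean on, the expected step in this assay is one of no clear direction and of a size not beyond the scatter. Taking compound 3 as the only anchor, compound 4 is estimated to give 30 ug/mL in this assay, with a range from 12 ug/mL to 75 ug/mL.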

Compound 4, half-maximal cytotoxic concentration: 9.6 ug/mL
Beside the measured number, compound 4's estimate is 3.1-fold (0.49 log units) above it; measured number outside the range, below it.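

Compound 4 differs in one place only from compound 1, whose entry in this assay carries no number, so no step can be read between them. The compounds shown leave open how far pyridin-4-yl in place of 2-fluorophenyl shifts the tolerated concentration. Nothing at hand bears on the result of compound 4.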